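A few compounds are considered here, and "the series" means these few. Any claim that something is new, unique, unknown or untested is made for them only; others in the source may bear on it.

Of the compounds shown here, two have so far been tested in an ADME assay on HepG2 cells (Homo sapiens) for cytotoxicity, read by CellTiter-Glo and resazurin assay, with a stated time of 72 h; a lower number here means that less compound is needed, a higher number that more compound is needed for the effect. Compound 1 `CC(C)COc1cccc(-c2ccc(C(=O)N(Cc3cccc(OCCCCCC(=O)O)c3)C(C)C)cc2)c1` gives > 26000 nM in this assay, and that is a limit of the measurement rather than a number. Compound 2 `CCOC(=O)CCCCCOc1cccc(CN(C(=O)c2ccc(-c3ccncc3)cc2)C(C)C)c1` gives > 26000 nM in this assay, again only a limit. Both results therefore rest at the limit of > 26000 nM in this assay, at which 2 of the 2 values shown sit, so nothing is known of compound 2 beyond that limit. Compound 3 `CCOC(=O)CCCCCOc1cccc(CN(C(=O)c2ccc(-c3cccc(OC)c3)cc2)C(C)C)c1` has not yet been measured. It differs from compound 2 in one place: 3-methoxyphenyl in place of pyridin-4-yl on an aromatic carbon. Going by the values given here, no measured pair shows what such a change does here, so the step can only be estimated. The expected step that the limit leaves unreadable from compound 2 to compound 3 is none beyond the usual scatter, because compound 2 itself sits at the limit of > 26000 nM in this assay, at which 2 of the 2 values shown sit. Compound 3 is thus expected to give about 30000 nM in this assay, somewhere between 13000 nM and 80000 nM, quite possibly reported again only as a limit.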

Compound 3, half-maximal effective concentration: > 21000 nM
Compound 3 ended at the assay's limit; the forecaster's own chance of this, stated with the estimate: 70%; the middle value is on the limit's open side.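

Compound 2 and compound 3 are both reported only as limits, so no step can be read for the change from pyridin-4-yl to 3-methoxyphenyl. The compounds shown leave open what concentration, if any, would reach the half-maximal effect in this assay.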